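The source may hold more compounds than are shown below. What is called first, only, known or untested is meant among the compounds shown, and "the series" means these compounds.

Working notes on the series. Compound 1 `Cc1sc2nc(-c3ccccn3)c(/C=N/NC(=N)N)n2c1C` is the reference point: in a functional assay on renal cells (Homo sapiens) for antiproliferative activity (a higher number here means a weaker inhibitor of growth, a lower number a stronger inhibitor of growth), compound 1 gives 6610 nM. Compound 2 `Cc1sc2nc(-c3ccncc3)c(/C=N/NC(=N)N)n2c1C` carries pyridin-4-yl in place of pyridin-2-yl on an aromatic carbon, and in this assay compound 2 gives 39800 nM. For the measured compounds named here, the only measured step is a 6.0-fold higher number from compound 1 to compound 2 (0.78 log units; beyond the scatter), so compound 1 stands at the lowest of the two numbers, with compound 2 the nearest neighbour at a clearly higher value.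

Compound 3 `Cc1cn2c(/C=N/NC(=N)N)c(-c3ccccn3)nc2s1` is the next variant. Its difference from compound 1 is hydrogen in place of methyl on an aromatic carbon. Going by the values given here, no measured step touches this change: the one step available concerns the pyridyl attachment, not the five-membered ring of the shared core, and its size therefore gives no direct guide. With nothing to anchor a direction, the working expectation is a step that stays close to the scatter, leaning if anything toward a slightly higher number, so that compound 3 is estimated to give 9000 nM, within 3500 nM to 25000 nM, which would amount to an expected step of a 1.4-fold higher number from compound 1 to compound 3 (0.13 log units; within the scatter).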

Compound 3, concentration for 50% growth inhibition: 7940 nM
Compound 3: middle estimate off by 1.1-fold (0.05 log units), on the high side; the measured number falls inside the stated range.
By their numbers in this assay, from the lowest: compounds 1 and 3 (each within the scatter of the next); then compound 2.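

In this assay the removal of this methyl gives a 1.2-fold higher number from compound 1 to compound 3 (0.08 log units; within the scatter) and so stays within the scatter, while the change of pyridyl attachment gives a 6.0-fold higher number from compound 1 to compound 2 (0.78 log units; beyond the scatter) and lies beyond it. With pyridin-2-yl in place, this aromatic carbon of the five-membered aromatic ring, next to the ring nitrogen, therefore carries either methyl or hydrogen with no difference that can be read in this assay. No measurement available here accounts for this result or bears on what lies behind it.

The compounds shown leave open whether this position tolerates only the smallest change or also larger or functionalised groups, such as an ethyl group, a longer chain, an amine or a carboxylic acid. Going by these compounds, it also remains open whether hydrogen in place of methyl would give a similarly small step with pyridin-4-yl on the shared core, and what replacing the other methyl, on the ring atom two ring bonds from the ring sulfur's neighbouring position, would do.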